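Pyridin-4-yl on the Amide Nitrogen: An Expected Step

The source may hold more compounds than are shown below. What is called first, only, known or untested is meant among the compounds shown, and "the series" means these compounds.

Measured compounds:
compound 1 `O=C(Nc1ccccn1)c1c(O)c2cccnc2n(-c2ccccc2)c1=O`: 14.6%
compound 2 `O=C(Nc1ccccc1)c1c(O)c2cccnc2n(-c2ccccc2)c1=O`: -15%
compound 3 `COc1ccc(NC(=O)c2c(O)c3cccnc3n(-c3ccccc3)c2=O)cc1`: -1.9%

In a functional assay on the whole organism for inhibition, with Rattus norvegicus as the target, read by cytopathic effect and paw edema, at a dose of 100 mg/kg by the oral route (on this read-out lower numbers stand for less inhibition and higher numbers for more inhibition at the one dose given (going by the name of the read-out)), compound 1 gives 14.6%, compound 2 gives -15% and compound 3 gives -1.9%. Compound 2 stands lowest of the three; its nearest neighbour is compound 3, with a number 13.1 percentage points higher from compound 2 to compound 3 (beyond the scatter), and the widest gap is to compound 1, with a number 29.6 percentage points lower from compound 1 to compound 2 (beyond the scatter) read in the other direction.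

Compound 4 `O=C(Nc1ccncc1)c1c(O)c2cccnc2n(-c2ccccc2)c1=O` is not yet measured. It differs from compound 2 in one place: pyridin-4-yl in place of phenyl on an amide-type nitrogen. Within the data shown here, the only measured step that bears on this change is the one between compound 1 and compound 2, a number 29.6 percentage points lower from compound 1 to compound 2 (beyond the scatter), where a ring nitrogen left the same position. Among the measured compounds shown here, compound 4 brings a ring nitrogen back, though as pyridin-4-yl rather than pyridin-2-yl, so compound 4 is expected to move upward in this assay by a number 19 percentage points higher from compound 2 to compound 4 (beyond the scatter), with the size uncertain since no pyridin-4-yl analogue has been measured. For compound 4 the estimated value in this assay is 4%, between -14% and 24%.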

Compound 4, a percentage reported as inhibition, in the whole organism at one dose (the size of the read-out at that dose, not a potency): 24.3%
Estimate against measurement, compound 4: 20.3 percentage points below, outside the stated range (above it).
By their numbers in this assay, from the lowest: compound 2; then compound 3; then compounds 1 and 4 (each within the scatter of the next).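

In this assay, pyridin-4-yl in place of phenyl on the amide-type nitrogen gives a number 39.3 percentage points higher from compound 2 to compound 4 (beyond the scatter), a large step, and pyridin-4-yl in place of 4-methoxyphenyl gives a number 26.2 percentage points higher from compound 3 to compound 4 (beyond the scatter), so the earlier rise with pyridin-2-yl is no longer confined to a single pyridine. Between the two pyridines the step is a number 9.7 percentage points higher from compound 1 to compound 4 (within the scatter), so the printed numbers do not separate pyridin-4-yl from pyridin-2-yl, and compounds 1 and 4 together stand apart from compounds 2 and 3. Nothing available gives a reason for this difference.

As far as these compounds go, it remains open whether pyridin-3-yl on the amide-type nitrogen would fall with compounds 1 and 4. Also open, from the compounds shown here alone, is whether an amine or a carboxylic acid on the phenyl ring of compound 2 would raise the number as a ring nitrogen does.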